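Swapping in an Amino Group on a Second Core

This account rests on a few compounds, and the source may have more. Where it says the series, first, only, none or still open, it means among the compounds named here.

Measured compounds:
compound 1, `COc1ccc(-c2cc3[nH]nc(-c4cc(OC)c(OC)c(OC)c4)n3n2)cc1`, 26800 nM
compound 2, `COc1ccc(-c2cc3[nH]nc(-c4cc(OC)c(OC)c(OC)c4)n3n2)cc1N`, 13800 nM
compound 3, `COc1ccc(-c2nn3c(-c4ccc(OC)c(OC)c4OC)nnc3s2)cc1`, 3750 nM

In a functional assay on SGC-7901 cells (Homo sapiens) for antiproliferative activity, read by MTT assay, with a stated time of 72 h (a lower number here means a stronger inhibitor, a higher number a weaker inhibitor), compound 1 gives 26800 nM. Adding an amino group, (amino in place of hydrogen on an aromatic carbon), gives compound 2 with 13800 nM, a step of a 1.9-fold lower number from compound 1 to compound 2 (0.29 log units; within the scatter). Compound 3 carries a different core; the difference between the two cores is not broken down here. In this assay compound 3 gives 3750 nM, lower than compound 1 and compound 2.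

Compound 4, `COc1ccc(-c2nn3c(-c4ccc(OC)c(OC)c4OC)nnc3s2)cc1N`, has not been measured. It differs from compound 3 by amino in place of hydrogen on an aromatic carbon, the same change as from compound 1 to compound 2. Because the earlier step was a 1.9-fold lower number from compound 1 to compound 2 (0.29 log units; within the scatter), a step of about a 1.9-fold lower number from compound 3 to compound 4 (0.27 log units; within the scatter) is expected here. Compound 4 is therefore estimated at 2000 nM in this assay, likely between 900 nM and 4500 nM.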

Compound 4, half-maximal inhibitory concentration: 62 nM
For compound 4 the middle estimate is 32-fold (1.51 log units) above the measured one; measured number outside the range, below it.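

In this assay, the amino group on the core of compound 3 gives a 60-fold lower number from compound 3 to compound 4 (1.78 log units; beyond the scatter), so the same change does not have the same size on the two cores: the same change on two cores in this assay, a 1.9-fold lower number (0.29 log units; within the scatter) from compound 1 to compound 2 and a 60-fold lower number (1.78 log units; beyond the scatter) from compound 3 to compound 4, 31-fold (1.49 log units) apart, beyond the scatter of two such steps

In this series, then, a step seen on one core is a poor guide to the step on the other. These compounds do not show why the two steps differ, and two cores say nothing about how the change would behave on a third.

From the compounds shown here alone, it remains open whether this large step is specific to the amino group, or whether a hydroxyl, a methylamino or an acetamide group in the same place on the core of compound 3 would give a similar one.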